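A few compounds are considered here, and "the series" means these few. Any claim that something is new, unique, unknown or untested is made for them only; others in the source may bear on it.

Three compounds of the series share one core and differ only in the group on a single aromatic carbon. Compound 1 `COc1ccc2c(c1)CN(C(=O)c1cc(S(C)(=O)=O)ccc1O[C@@H](C)C(F)(F)F)C2` carries methoxy there, and in an assay on CHO cells for inhibition of sodium- and chloride-dependent glycine transporter 1 (Homo sapiens), read by scintillation counting (a higher number here means that more compound is needed for the effect, a lower number that less compound is needed), compound 1 gives 180 nM. Compound 2 `C[C@H](Oc1ccc(S(C)(=O)=O)cc1C(=O)N1Cc2ccc(N3CCCC3)cc2C1)C(F)(F)F` carries pyrrolidin-1-yl, and in this assay compound 2 gives 180 nM. Compound 3 `C[C@H](Oc1ccc(S(C)(=O)=O)cc1C(=O)N1Cc2ccc(C3CCCCO3)cc2C1)C(F)(F)F` carries oxan-2-yl; in this assay compound 3 gives 205 nM. The step of no change at the digits printed from compound 1 to compound 2 (within the scatter) shows that exchanging methoxy for pyrrolidin-1-yl leaves the number where it was; a 1.1-fold higher number from compound 1 to compound 3 (0.06 log units; within the scatter) and a 1.1-fold higher number from compound 2 to compound 3 (0.06 log units; within the scatter) are likewise inside the scatter, so compound 3 sits among the other two without any separation the assay would resolve.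

Compound 4 `C[C@H](Oc1ccc(S(C)(=O)=O)cc1C(=O)N1Cc2ccc(C3CCOCC3)cc2C1)C(F)(F)F` is the next member: oxan-4-yl in place of oxan-2-yl on an aromatic carbon. The measured steps that bear on this change are those made at the same aromatic carbon, a 1.1-fold higher number from compound 1 to compound 3 (0.06 log units; within the scatter) and a 1.1-fold higher number from compound 2 to compound 3 (0.06 log units; within the scatter), both within the scatter, and no step beyond the scatter has been seen at this position with any of the three groups tried. Compound 4 is therefore expected to show a step of a 1.0-fold lower number from compound 3 to compound 4 (0.01 log units; within the scatter) in this assay, which is to say none beyond the scatter. The estimate for compound 4 in this assay is 200 nM, with a range from 110 nM to 400 nM.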

Compound 4, half-maximal effective concentration: 14 nM
Estimate against measurement, compound 4: 14-fold (1.15 log units) above, and the stated range ends above it.
By their numbers in this assay, from the lowest: compound 4; then compounds 1, 2 and 3 (each within the scatter of the next).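

In this assay the point of attachment alone carries a large effect: oxan-4-yl in place of oxan-2-yl gives (a 15-fold lower number from compound 3 to compound 4 (1.17 log units; beyond the scatter)), although the group that leaves and the group that enters have the same atoms, the same six-membered ring and the same counts of donors and acceptors. The position is therefore not indifferent, as methoxy, pyrrolidin-1-yl and oxan-2-yl alone had suggested, since oxan-4-yl also separates clearly from the other two groups, with (a 13-fold lower number from compound 2 to compound 4 (1.11 log units; beyond the scatter)) and (a 13-fold lower number from compound 1 to compound 4 (1.11 log units; beyond the scatter)), while compounds 1, 2 and 3 remain within the scatter of one another. Nothing measured here accounts for the difference between the two oxanyl attachments.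

Still open, as far as these compounds go, is whether the low number depends on the ring oxygen in this placement, which oxan-3-yl, cyclohexyl or piperidin-4-yl at the same aromatic carbon would test. Equally open, from the compounds shown here alone, is whether oxan-4-yl keeps this advantage when the other parts of the shared core change, for instance with a different group in place of the methylsulfonyl.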